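A furan-2-yl swap starting from the assay limit

The compounds below may be only part of what the source reports. "The series", "measured", "known", "first", "only" and "open" are said of these compounds alone.

In a functional assay on MGC-803 cells (Homo sapiens) for antiproliferative activity, read by MTT assay, with a stated time of 72 h (a higher number here means a weaker inhibitor, a lower number a stronger inhibitor), compound 2 (`O=C(N/N=C/c1ccco1)c1cccc(S(=O)(=O)N2CCOCC2)c1`) gives > 100000 nM as its result, which is a limit of the assay and not a number. Compound 1 (`C/C(=N\NC(=O)c1cccc(S(=O)(=O)N2CCOCC2)c1)c1cccc(N)c1`) gives > 100000 nM in this assay and this too is a limit. The record so far is therefore very simple (the limit of > 100000 nM in this assay, at which 2 of the 2 values shown sit). Among the measured compounds shown here, neither compound yields a true number, so no measured step is available to show how large a structural change might be.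

Compound 3 (`O=C(N/N=C/c1ccccc1O)c1cccc(S(=O)(=O)N2CCOCC2)c1`) keeps the rest of compound 2 but carries 2-hydroxyphenyl in place of furan-2-yl on a carbon with a double bond to nitrogen. In this assay a modest shift towards a stronger inhibitor is expected, although another limit would be no surprise. The estimated change is an at least 1.6-fold lower number from compound 2 to compound 3 (0.22 log units; that floor lies within the scatter) in size, and it starts from a limit, so it is a rough guide only. The estimate for compound 3 is 60000 nM (expected range 10000 nM to 200000 nM).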

Compound 3, half-maximal inhibitory concentration: 25300 nM
Compound 3: the middle estimate sits 2.4-fold (0.38 log units) above what was measured; the measured number falls inside the stated range.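

Among the compounds shown here, this carbon with a double bond to nitrogen is the first place where a single change moves the result in this assay off the limit. Compound 3 supplies the first true number, 25300 nM. Replacing furan-2-yl with 2-hydroxyphenyl gives an at least 3.9-fold lower number from compound 2 to compound 3 (0.59 log units; beyond the scatter), so the group at this place can change the result, although only a floor for the step can be read, as it starts from a limit. The swap changes several things at once, bringing a six-membered aromatic ring of carbon only in place of a five-membered aromatic ring with a hetero atom and adding a hydrogen-bond donor, and this one step cannot separate those changes, while the record still holds only one true number: the limit of > 100000 nM in this assay, at which 2 of the 3 values shown sit.

Going by these compounds, whether the hydroxyl matters, or the six-membered ring alone would give the same result, remains open, and a plain phenyl group or a methoxy or amine group in place of the hydroxyl would help to decide this. On these data alone, it is also open how much lower the number can go with other groups at this place, and whether the rest of the shared core affects the result.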